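Replacing the thiazole of compound 1 with a hydroxyphenyl

A few compounds are considered here, and "the series" means these few. Any claim that something is new, unique, unknown or untested is made for them only; others in the source may bear on it.

Compound 1 `Cc1cccc(NC(=O)CN2CCC(c3nccs3)CC2)c1`: 1 nM
Compound 2 `O=C(NCN1CCC(c2cccc[n+]2[O-])CC1)c1cnccc1Cl`: 1290 nM
Compound 3 `COc1cccc(C)c1NC(=O)CN1CCC(c2cccc[n+]2[O-])CC1`: 340 nM

Of the compounds shown here, three have been measured in a functional assay on HEK293 cells for agonist activity at D(4) dopamine receptor (Homo sapiens), read by FLIPR; a higher number here means that more compound is needed for the effect, a lower number that less compound is needed. Compound 1 gives 1 nM, the lowest of the three numbers. Compound 3 gives 340 nM, and compound 2 gives 1290 nM; both lie far beyond the scatter from compound 1, and compound 1 is the most potent of the set. Going by the values given here, compounds 2 and 3 differ from compound 1 in more than one place, so no single step between them can be read.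

Compound 4 `Cc1cccc(NC(=O)CN2CCC(c3cccc(O)c3)CC2)c1` has not yet been measured. It differs from compound 1 in one place: 3-hydroxyphenyl in place of 1,3-thiazol-2-yl on a saturated ring carbon. Among the compounds with values here, with no single-point step on record, the expectation rests on compound 1 alone and on the size of the change. Because compound 1 gives 1 nM, a move away from its value is expected, in the direction of a higher number, beyond the scatter but well short of the gap to compound 3. The step from compound 1 to compound 4 is expected to be a 20-fold higher number from compound 1 to compound 4 (1.30 log units; beyond the scatter). Compound 4 is estimated at 20 nM, within a range from 3 nM to 150 nM.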

Compound 4, half-maximal effective concentration: 8 nM
Beside the measured number, compound 4's estimate is 2.5-fold (0.40 log units) above it, and the stated range covers the measured number.
By their numbers in this assay, from the lowest: compound 1; then compound 4; then compound 3; then compound 2.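

In this assay, going by these compounds alone, the step of an 8.0-fold higher number from compound 1 to compound 4 (0.90 log units; beyond the scatter) gives the first reading of a single change at this saturated ring carbon, three ring bonds from the ring nitrogen. Replacing 1,3-thiazol-2-yl with 3-hydroxyphenyl moves the number beyond the scatter, but the step is modest, and compound 4 still gives 8 nM with a six-membered aromatic ring of carbon only in this place. The data therefore show that this position does not depend on keeping the thiazole, and no measurement at hand accounts for the size of the step.

The compounds shown leave open whether the hydroxyl itself counts here, since the values give no reading for an unsubstituted phenyl or a methoxyphenyl at this carbon. They also leave open how a 2-thienyl or 2-pyridyl ring would compare with the thiazole.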